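Dropping the Amide Methyl From Compound 1

This account rests on a few compounds, and the source may have more. Where it says the series, first, only, none or still open, it means among the compounds named here.

Compound 1, `CNC(=O)/C=C1\CCc2ccc(Br)cc21`, was tested in a functional assay on the whole organism with Rattus norvegicus as the target, at a dose of 20 mg/kg by the oral route (on this read-out lower numbers stand for less inhibition and higher numbers for more inhibition at the one dose given (going by the name of the read-out)), where compound 1 gives 44%. Among the three compounds measured it holds the second highest number. Compound 3, `CNC(=O)/C=C1\CCc2ccc(F)cc21`, gives 45%, and the step of a number 1 percentage points higher from compound 1 to compound 3 (within the scatter) stays within the scatter, so these two cannot be ordered. Compound 2, `CNC(=O)/C=C1\CCc2ccc(Cl)cc21`, gives 0%; the step of a number 44 percentage points lower from compound 1 to compound 2 (beyond the scatter) is large, as is the step of a number 45 percentage points higher from compound 2 to compound 3 (beyond the scatter).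

Compound 4, `NC(=O)/C=C1\CCc2ccc(Br)cc21`, differs from compound 1 in one place: hydrogen in place of methyl on an amide-type nitrogen. Within the data shown here, every measured step concerns a halogen on an aromatic carbon; none touches the amide-type nitrogen, so no measured step bears directly on this change. With nothing to anchor a direction, the expected step of a number 4 percentage points lower from compound 1 to compound 4 (within the scatter) is taken as no change beyond the scatter, though the wide spread among the halogen analogues warns that single values in this assay can move far. Compound 4 is therefore expected to give about 40%, within a range from 5% to 70%.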

Compound 4, a percentage reported as inhibition, in the whole organism at one dose (the size of the read-out at that dose, not a potency): 38%
Compound 4: the middle estimate sits 2 percentage points above what was measured; low and high end bracket the measured number.
By their numbers in this assay, from the lowest: compound 2; then compounds 4, 1 and 3 (each within the scatter of the next).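

Among these compounds, the step of a number 6 percentage points lower from compound 1 to compound 4 (within the scatter) in this assay is the first look at the amide-type nitrogen, as all the earlier steps concerned only the halogen on the aromatic carbon. It shows that, with the bromo group kept, hydrogen can take the place of methyl on this nitrogen without a shift beyond the usual scatter, so the methyl is not required for this read-out at the one dose given. Nothing measured here explains why the read-out holds across this change.

Going by these compounds, it remains open whether a longer chain on this nitrogen, such as ethyl or propyl, or a carboxylic acid in place of the whole methylcarbamoyl group, would leave the read-out unchanged. On these data alone, it is also open whether the same swap of methyl for hydrogen would behave alike in the chloro and fluoro compounds.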